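Sulfonamide series: fluorophenyl variant of compound 1

The source may hold more compounds than are shown below. What is called first, only, known or untested is meant among the compounds shown, and "the series" means these compounds.

Compound 1 `COc1ccc(S(=O)(=O)Nc2ccc(-c3nc4ccccc4o3)cc2)cc1` carries a 4-methoxyphenyl on the sulfonyl sulfur. In an assay on cells for inhibition of HSP60/HSP10 (Homo sapiens), with a stated time of 60 min (a lower number here means a stronger inhibitor, a higher number a weaker inhibitor), compound 1 gives > 100000 nM, which is a limit of the assay and not a number. Among the compounds with values here, compound 2 `Cc1ccccc1S(=O)(=O)Nc1ccc2oc(-c3ccccc3)nc2c1` and compound 3 `Cc1cccc(S(=O)(=O)Nc2ccc3oc(-c4ccccc4)nc3c2)c1` are the other two members measured so far. In this assay compound 2 gives > 100000 nM, again a limit. In this assay compound 3 gives > 100000 nM, also a limit. The step that the two limits leave unreadable from compound 2 to compound 3 cannot be read for that reason. Within the data shown here, all values measured so far sit at the limit of > 100000 nM in this assay, at which 3 of the 3 values shown sit.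

Compound 4 `O=S(=O)(Nc1ccc(-c2nc3ccccc3o2)cc1)c1cccc(F)c1` differs from compound 1 by 3-fluorophenyl in place of 4-methoxyphenyl on a sulfonyl sulfur. Among the measured compounds shown here, the only measured step that changes the group on the sulfonyl sulfur is a step that the two limits leave unreadable from compound 2 to compound 3, and its size is hidden by the limit, so no readable step bears on the change from compound 1 to compound 4. The expected step of a number no higher from compound 1 to compound 4 (the limit leaves the size open) is therefore none beyond the scatter. Compound 4 is expected to remain at the limit, estimated at 100000 nM with a range of 30000 nM to 300000 nM.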

Compound 4, half-maximal inhibitory concentration: 71000 nM
Beside the measured number, compound 4's estimate is 1.4-fold (0.15 log units) above it; the measured number falls inside the stated range.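

The group on the sulfonyl sulfur can move this series off the limit: with 3-fluorophenyl in place of 4-methoxyphenyl, this assay gives its first number and not a limit, and the step reads an at least 1.4-fold lower number from compound 1 to compound 4 (0.14 log units; that floor lies within the scatter). On these data alone, that floor does not show a change beyond the scatter, and the full size of the step remains unknown. Within the data shown here, compound 4 is the only member with a readable value, while the others stay at the limit: the limit of > 100000 nM in this assay, at which 3 of the 4 values shown sit.

Among these compounds, the step between the two methylphenyl compounds cannot be read, so this change on the sulfonyl sulfur has no second readable step to support it. As far as these compounds go, it remains open whether unsubstituted phenyl, 4-fluorophenyl, or a phenyl carrying an amine or a carboxylic acid at this place would give a lower number than compound 4, beyond the scatter.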